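This account rests on a few compounds, and the source may have more. Where it says the series, first, only, none or still open, it means among the compounds named here.

Compound 3 `COc1ccccc1N1CCN(CCC(Oc2ccc(C(=O)Nc3ccccc3OCCCC(=O)O)cc2)c2cccc(C)c2)CC1` gives the highest number among the three compounds measured in an assay on Prostate gland (Oryctolagus cuniculus) for inhibition of Adrenergic receptor alpha-1 (Homo sapiens) (on this read-out higher numbers stand for weaker binding and lower numbers for tighter binding), at 251 nM. Compound 2 `CCc1ccc(C(CCN2CCN(c3ccccc3OC)CC2)Oc2ccc(NC(=O)c3ccccc3OCCCC(=O)O)cc2)cc1` gives 200 nM, and compound 1 `COc1ccccc1N1CCN(CCCOc2ccc(C(=O)Nc3ccccc3OCCCC(=O)O)cc2)CC1` gives 100 nM; only the gap between compound 3 and compound 1 lies beyond the scatter. Compound 4 `COc1ccc(C(CCN2CCN(c3ccccc3OC)CC2)Oc2ccc(C(=O)Nc3ccccc3OCCCC(=O)O)cc2)cc1` differs from compound 3 in one place: 4-methoxyphenyl in place of 3-methylphenyl on a saturated chain carbon bound to an oxygen on an aromatic ring and a saturated chain carbon. Going by the values given here, no measured step swaps one aryl group for another on this saturated chain carbon. Among the compounds with values here, the one step that touches it, a 2.5-fold higher number from compound 1 to compound 3 (0.40 log units; beyond the scatter), shows that placing an aryl group there moves the number modestly. Compound 2, which carries its own aryl group on the same saturated chain carbon, and compound 3 give numbers that lie within the scatter of each other, so the choice of aryl group has not yet shown a clear effect. The expectation for compound 4 is therefore a step that stays within the scatter, a 1.1-fold lower number from compound 3 to compound 4 (0.06 log units; within the scatter). Compound 4 is estimated at 220 nM, with a range from 100 nM to 500 nM.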

Compound 4, dissociation constant: 200 nM
Beside the measured number, compound 4's estimate is 1.1-fold (0.04 log units) above it, within the range that was stated.
By their numbers in this assay, from the lowest: compounds 1, 2, 4 and 3 (each within the scatter of the next, the first and the last beyond it).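

Going by these compounds alone, this is the first measured swap of one aryl group for another on this saturated chain carbon, and in this assay 4-methoxyphenyl in place of 3-methylphenyl gives a 1.3-fold lower number from compound 3 to compound 4 (0.10 log units; within the scatter), so the two groups cannot be told apart here. Against hydrogen on the same carbon, 4-methoxyphenyl gives a 2.0-fold higher number from compound 1 to compound 4 (0.30 log units; within the scatter), while 3-methylphenyl gives a 2.5-fold higher number from compound 1 to compound 3 (0.40 log units; beyond the scatter); the two steps fall on either side of the scatter limit, so the modest shift seen with the first aryl group is not firmly repeated with the second. Nothing available here explains these numbers.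

The compounds shown leave open whether an aromatic ring is needed on this carbon at all, which a cyclohexyl or a plain methyl group there would test. They also leave open how a ring carrying an amine would read.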